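Aryl-methoxy variation in a pentylamine-linked diether series

The source may report more compounds than this note shows. Statements on the series, on what has been measured and on what is new or still open speak of the compounds shown alone.

Measured so far in a functional assay on SK-OV-3 cells (Homo sapiens) for inhibition, read by CCK-8 assay, with a stated time of 70 h; on this read-out lower numbers stand for stronger inhibition and higher numbers for weaker inhibition:
- compound 1, `COc1ccc(COc2ccc(OCCOCCNC3CCCC3)cc2)cc1`, gives 15700 nM
- compound 2, `Nc1ccccc1COc1ccc(OCCOCCNC2CCCC2)cc1`, gives 14000 nM
- compound 3, `O=Cc1ccc(COc2ccc(OCCOCCNC3CCCC3)cc2)cc1`, gives 45000 nM

Compound 3 stands as the highest number of the three in this assay; the nearest is compound 1 at a 2.9-fold higher number from compound 1 to compound 3 (0.46 log units; beyond the scatter), and the furthest is compound 2 at a 3.2-fold higher number from compound 2 to compound 3 (0.51 log units; beyond the scatter). Compounds 1 and 2 differ only by a 1.1-fold lower number from compound 1 to compound 2 (0.05 log units; within the scatter), so those two cannot be ordered.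

Compound 4, `COC(=O)c1ccccc1COc1ccc(OCCOCCNC2CCCC2)cc1`, has not yet been measured. It differs from compound 3 as follows: 2-(methoxycarbonyl)phenyl in place of 4-formylphenyl on a saturated chain carbon bound to an oxygen on an aromatic ring. Both steps that lead into compound 3 bear on this change, since both replace the 4-formylphenyl end with a different substituted phenyl and both sit beyond the scatter in the same direction. Compound 2 already carries a 2-substituted phenyl at this place and gives 14000 nM, so a return toward the range of compounds 1 and 2 is expected; with no ester yet measured in the series the direction is inferred, not shown.

Compound 4 is therefore estimated at 18000 nM, between 7000 nM and 45000 nM, in this assay. This estimate means a step of a 2.5-fold lower number from compound 3 to compound 4 (0.40 log units; beyond the scatter), expected to be modest and in the lower direction.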

Compound 4, half-maximal inhibitory concentration: > 100000 nM
Compound 4: a limit, no number (the forecaster's own chance of this, stated with the estimate: 10%); middle value at least 5.5-fold (0.74 log units) from the limit.
By their numbers in this assay, from the lowest: compounds 2 and 1 (each within the scatter of the next); then compound 3. At a limit, above all of these: compound 4.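

In this assay compound 4 gives > 100000 nM, which is a limit of the assay and not a number: the limit of > 100000 nM in this assay, at which 1 of the 4 values shown sits.

On a saturated chain carbon bound to an oxygen on an aromatic ring, the 2-(methoxycarbonyl)phenyl end gives an at least 2.2-fold higher number from compound 3 to compound 4 (0.34 log units; beyond the scatter) and an at least 6.3-fold higher number from compound 1 to compound 4 (0.80 log units; beyond the scatter); methoxycarbonyl in place of amino on an aromatic carbon gives an at least 7.1-fold higher number from compound 2 to compound 4 (0.85 log units; beyond the scatter). The 2-aminophenyl and 2-(methoxycarbonyl)phenyl ends therefore part clearly, so a 2-substituted phenyl does not by itself keep the number in the range of compound 2.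

From the compounds shown here alone, how far compound 4 lies past its limit stays open, so the full size of these steps cannot be read. Also open, going by these compounds, is whether the ester or its ring place drives the step, which a 4-(methoxycarbonyl)phenyl or 2-carboxyphenyl end would test.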